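Sulfonamide size on a shared bicyclic core

The source may hold more compounds than are shown below. What is called first, only, known or untested is meant among the compounds shown, and "the series" means these compounds.

Of the compounds shown here, two sharing one core have been measured in a functional assay on CHO cells for agonist activity at Alpha-1A adrenergic receptor (Homo sapiens), read by FLIPR and calcium flux; a lower number here means that less compound is needed, a higher number that more compound is needed for the effect. Compound 1 `CCCS(=O)(=O)Nc1cccc2c1CCC2c1ncc[nH]1` carries a (propylsulfonyl)amino group on an aromatic carbon; in this assay compound 1 gives 1340 nM. Compound 2 `c1ccc2c(c1)CCC2c1ncc[nH]1` has only hydrogen at that position, and in this assay compound 2 gives 473 nM. This is the lower of the two numbers: the step of a 2.8-fold lower number from compound 1 to compound 2 (0.45 log units; beyond the scatter) shows that removing the sulfonamide lowers the amount of compound needed.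

Compound 3 `CS(=O)(=O)Nc1cccc2c1CCC2c1ncc[nH]1` sits between these two. The change from compound 2 is methanesulfonamido in place of hydrogen on an aromatic carbon, so a shorter sulfonamide returns to the position where compound 1 carries the longer one. Going by the values given here, the only step that bears on this is a 2.8-fold lower number from compound 1 to compound 2 (0.45 log units; beyond the scatter), which ran in the opposite direction with a modest size. A sulfonamide of smaller size is therefore expected to raise the number again, though perhaps by less than the full amount seen for compound 1. The expected step of a 1.9-fold higher number from compound 2 to compound 3 (0.28 log units; within the scatter) is estimated to be modest. For compound 3 the estimate in this assay is 900 nM, with a range from 400 nM to 2000 nM.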

Compound 3, half-maximal effective concentration: 70 nM
Compound 3: the middle estimate sits 13-fold (1.11 log units) above what was measured, outside the stated range (below it).
By their numbers in this assay, from the lowest: compound 3; then compound 2; then compound 1.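

In this assay, placing methanesulfonamido on this aromatic carbon gives a 6.8-fold lower number from compound 2 to compound 3 (0.83 log units; beyond the scatter), so a sulfonamide here can lower the number rather than raise it, which compound 1 and compound 2 alone gave no hint of. The two sulfonamides differ in one place only, and hydrogen in place of ethyl on the saturated chain carbon bound to the sulfonyl sulfur gives a 19-fold lower number from compound 1 to compound 3 (1.28 log units; beyond the scatter), a large step for such a small edit. The outcome at this position therefore depends on what the sulfonyl group carries, not simply on whether a sulfonamide is present, and compound 3 ends up with the lowest number of the three, while the longer propyl version in compound 1 has the highest.

On these data alone, it remains open whether the number climbs steadily with chain length, as ethanesulfonamido would show, or whether an acetamido group or a plain amine on this aromatic carbon would also lower it. Nothing available explains why removing the ethyl changes the number so much.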